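Swapping a Methoxyphenyl for Difluorophenyl on a Carbonyl

The source may report more compounds than this note shows. Statements on the series, on what has been measured and on what is new or still open speak of the compounds shown alone.

Of the compounds shown here, three sharing one core have been tested in a functional assay on TK-10 cells (Homo sapiens) for cytotoxicity, read by sulforhodamine B assay, with a stated time of 48 h, tested at 10 uM; on this read-out lower numbers stand for a stronger effect and higher numbers for a weaker effect at the one concentration tested. Compound 1 `COc1ccc(-c2cc(/C=C/C(=O)c3ccc(N)cc3)[nH]n2)cc1` gives 12%, compound 2 `COc1ccc(C(=O)/C=C/c2cc(-c3cc(OC)c(OC)c(OC)c3)n[nH]2)cc1` gives -29%, and compound 3 `COc1cc(C(=O)/C=C/c2cc(-c3cc(OC)c(OC)c(OC)c3)n[nH]2)cc(OC)c1OC` gives -98%. Compound 2 thus stands second highest of the three: its nearest neighbour is compound 1, higher by an amount beyond the scatter, and its furthest is compound 3, lower by an amount also beyond the scatter. Compound 4 `COc1cc(-c2cc(/C=C/C(=O)c3ccc(F)c(F)c3)[nH]n2)cc(OC)c1OC` has not yet been measured in this assay. It differs from compound 2 in one place: 3,4-difluorophenyl in place of 4-methoxyphenyl on a carbonyl carbon. Among the compounds with values here, no matching step between measured compounds exists here, so the outcome is uncertain. The expected step is a number 11 percentage points lower from compound 2 to compound 4 (beyond the scatter), a modest move toward a stronger effect that may yet sit within the scatter. Compound 4 is estimated at -40%, in a range from -90% to 10%.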

Compound 4, a percentage reported as activity, at one concentration (the size of the read-out at that concentration, not a potency): -13%
Beside the measured number, compound 4's estimate is 27 percentage points below it, and the stated range covers the measured number.
By their numbers in this assay, from the lowest: compound 3; then compound 2; then compound 4; then compound 1.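

Placing 3,4-difluorophenyl in place of 4-methoxyphenyl on a carbonyl carbon gives, in this assay, a number 16 percentage points higher from compound 2 to compound 4 (beyond the scatter), the only step that can be read at this position, and it runs toward a weaker effect. The effect is not abolished, since compound 4 still gives -13%. No supporting data bear on why the step runs this way.

As far as these compounds go, whether the loss of methoxy or the arrival of fluorine drives this step stays open. So does how a 4-chlorophenyl group would read at this carbonyl carbon.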